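Carbamoyl in place of bromo: an expectation of weak activity

A few compounds are considered here, and "the series" means these few. Any claim that something is new, unique, unknown or untested is made for them only; others in the source may bear on it.

compound 1 `CCCNC(=O)c1oc2c(C(N)=O)c(OC)cc(OC)c2c1C`: > 93600 nM
compound 2 `COc1cc(OC)c2c(C)c(C=O)oc2c1Br`: "not active" (no number reported)

In a functional assay on NSCLC-N6 cells (Homo sapiens) for cytotoxicity, read by MTT assay (a higher number here means a weaker inhibitor, a lower number a stronger inhibitor), compound 2 gives "not active" (no number reported), so no number is attached to it. For compound 1 the value shown is a limit of the assay, > 93600 nM. Among the measured compounds shown here, compound 2 therefore stands without a number of its own, and the only other value is the limit of > 93600 nM in this assay, at which 1 of the 2 values shown sits. Compound 3 `COc1cc(OC)c2c(C)c(C=O)oc2c1C(N)=O` differs from compound 2 by carbamoyl in place of bromo on an aromatic carbon, in words carbamoyl in place of bromo on an aromatic carbon. For the measured compounds named here, no step between measured compounds exists to guide the size of this change; with both measured results weak, a change beyond the usual scatter in either direction cannot be read from these data, and a weak result is expected once more. Compound 3 is estimated at 100000 nM, between 30000 nM and 300000 nM in this assay, most likely reported again as a limit rather than a number.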

Compound 3, half-maximal inhibitory concentration: 44400 nM
Estimate against measurement, compound 3: 2.3-fold (0.35 log units) above, within the range that was stated.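

In this assay, among the compounds shown here, compound 3 gives 44400 nM, the only true number, so with carbamoyl on this aromatic carbon, para to a methoxy group, the compound registers a measurable effect. With bromo at the same place, compound 2 is reported as "not active" (no number reported), and the step between these two cannot be read in size. At the other end of the molecule, hydrogen in place of propylamino on the carbonyl carbon, with carbamoyl kept, gives an at least 2.1-fold lower number from compound 1 to compound 3 (0.32 log units; beyond the scatter).

Going by these compounds, compound 1 is held only by a limit, so the full size of that step stays open: the limit of > 93600 nM in this assay, at which 1 of the 3 values shown sits. On these data alone, whether an amine or a carboxylic acid in place of carbamoyl, or a longer chain on the carbonyl carbon, would bring the number lower also stays open.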